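Removing a Chloro Group from the Aryl Ring

This account rests on a few compounds, and the source may have more. Where it says the series, first, only, none or still open, it means among the compounds named here.

Compound 2 `Cc1cc(Cl)cc(-c2c(C)nn(-c3nc(-c4ccc(Cl)c(Cl)c4)c(SC(C)C)s3)c2C(=O)O)c1` gives the lowest of the two numbers in a functional assay on BJAB cells (Homo sapiens) for antiproliferative activity, with a stated time of 4 days (on this read-out higher numbers stand for an effect only at larger amounts of compound and lower numbers for an effect already at smaller amounts), with 663 nM. Compound 1 `COc1cc(-c2c(C)nn(-c3nc(-c4ccc(Cl)c(Cl)c4)c(SC(C)C)s3)c2C(=O)O)cc(C(F)(F)F)c1` gives 1380 nM. Among the measured compounds shown here, the one measured step, a 2.1-fold lower number from compound 1 to compound 2 (0.32 log units; beyond the scatter), swapped the whole aryl group. Compound 3 `Cc1cccc(-c2c(C)nn(-c3nc(-c4ccc(Cl)c(Cl)c4)c(SC(C)C)s3)c2C(=O)O)c1` differs from compound 2 by hydrogen in place of chloro on an aromatic carbon. For the measured compounds named here, no measured step removes a single substituent from this ring, so that aryl swap bears on the change only loosely. Compound 3 is therefore expected to show a modest step of a 1.7-fold higher number from compound 2 to compound 3 (0.22 log units; within the scatter) toward a higher number, with an estimate of 1100 nM (500 nM to 2500 nM).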

Compound 3, half-maximal effective concentration: 17000 nM
Compound 3: middle estimate off by 15-fold (1.19 log units), on the low side; measured number outside the range, above it.
By their numbers in this assay, from the lowest: compound 2; then compound 1; then compound 3.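

In this assay, this chloro group proves to matter far more than the aryl swap suggested: its replacement by hydrogen gives a 26-fold higher number from compound 2 to compound 3 (1.41 log units; beyond the scatter), well beyond a 2.1-fold lower number from compound 1 to compound 2 (0.32 log units; beyond the scatter). The single-substituted 3-methylphenyl ring also compares poorly with the doubly substituted ring, giving a 12-fold higher number from compound 1 to compound 3 (1.09 log units; beyond the scatter), so either second substituent goes with a lower number than hydrogen. Nothing measured here accounts for the size of this loss. The compounds shown leave open whether a bromo group, a nitrile or an amine in this place would keep the lower number, and whether the chloro group alone, without the methyl group, would suffice.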